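The source may report more compounds than this note shows. Statements on the series, on what has been measured and on what is new or still open speak of the compounds shown alone.

In a functional assay on NCI-H460 cells (Homo sapiens) for inhibition, read by MTT assay, with a stated time of 24 h, tested at 0.1 ug/mL (on this read-out higher numbers stand for more inhibition of growth at the one concentration tested and lower numbers for less inhibition of growth), compound 1, with the structure `O=C(CCCCC(S)CCS)Nc1ccccc1`, gives 5.5%. Compound 2, with the structure `O=C(CCCCC(S)CCS)Nc1ccccc1Cl`, differs from it by chloro in place of hydrogen on an aromatic carbon and gives 6.36% in this assay, so that the change amounts to a number 0.9 percentage points higher from compound 1 to compound 2 (within the scatter). Compound 3, with the structure `CC(=O)SCCC(CCCCC(=O)Nc1ccccc1)SC(C)=O`, gives 15.4% in this assay; how its core differs from the core of compound 1 is not broken down here, and the two values are within the usual scatter of each other. Compound 4, with the structure `CC(=O)SCCC(CCCCC(=O)Nc1ccccc1Cl)SC(C)=O`, has not yet been measured. It stands to compound 3 as compound 2 stands to compound 1: the difference is chloro in place of hydrogen on an aromatic carbon, at the same place in both pairs, so the change is the same. For compound 4 the step of a number 1.1 percentage points higher from compound 3 to compound 4 (within the scatter) is expected to be small, because a number 0.9 percentage points higher from compound 1 to compound 2 (within the scatter) stayed within the scatter in the measured pair. Compound 4 is therefore estimated at 16.5% in this assay, between 5% and 28%.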

Compound 4, percent growth inhibition at one concentration: 16.6%
Compound 4: the middle estimate sits 0.1 percentage points below what was measured; measured number inside the range.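

In this assay the change from phenyl to 2-chlorophenyl gives a number 1.2 percentage points higher from compound 3 to compound 4 (within the scatter), and the same change reads alike on the core of compound 1 and on the core of compound 3: the same change on two cores in this assay, a number 0.9 percentage points higher (within the scatter) from compound 1 to compound 2 and a number 1.2 percentage points higher (within the scatter) from compound 3 to compound 4, 0.3 percentage points apart, within the scatter of two such steps

So in this series, the change carried from one core to the other without any departure that these numbers can detect, and a step read on one of these two cores served as a fair guide to the step on the other. Among the compounds shown here, this does not show that the chloro group has any real effect on growth inhibition on either core, as both steps lie within the scatter, and the agreement rests on only two pairs, with the chloro group ortho to a large group and a single concentration tested.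

The compounds shown leave open whether another group at that place, such as fluoro, methoxy or a carboxylic acid, would also give steps that match across the two cores. They also leave open whether the match would hold on a core with a longer chain.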